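The source may hold more compounds than are shown below. What is called first, only, known or untested is meant among the compounds shown, and "the series" means these compounds.

Of the compounds shown here, three that share one core have been measured in an ADME assay on microsomes from liver (Homo sapiens) for metabolic stability, tested at 2.5 uM; a lower number here means slower removal, a higher number faster removal of the compound. Compound 1 `O=S(=O)(c1ccc(F)cc1)c1cnc2cc(F)ccc2c1-c1cccc(F)c1` gives 0.95 mL/min. Compound 2 `COc1ccc(S(=O)(=O)c2cnc3cc(F)ccc3c2-c2cccc(F)c2)cc1Cl` gives 2.08 mL/min, and compound 3 `O=S(=O)(c1cc(F)cc(F)c1)c1cnc2cc(F)ccc2c1-c1cccc(F)c1` gives 0.06 mL/min, the lowest of the three numbers. The three differ only in the group on the sulfonyl sulfur: a 2.2-fold higher number from compound 1 to compound 2 (0.34 log units; beyond the scatter), a 16-fold lower number from compound 1 to compound 3 (1.20 log units; beyond the scatter), and a 35-fold lower number from compound 2 to compound 3 (1.54 log units; beyond the scatter). Compound 3 therefore stands clearly apart from the other two, with markedly slower removal than either.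

Compound 4 `COc1ccc(-c2c(S(=O)(=O)c3cc(F)cc(F)c3)cnc3cc(F)ccc23)cc1` has not yet been measured. It keeps the 3,5-difluorophenyl of compound 3 on the sulfonyl sulfur and changes a different part of the molecule: 4-methoxyphenyl in place of 3-fluorophenyl on an aromatic carbon. For the measured compounds named here, none of the measured steps bears directly on this change; all of them alter the group on the sulfonyl sulfur, so they show how wide the swings in this assay can be but give no direct guide to the aromatic carbon that is changed here. In the absence of a matching step, the expected change is a 2.5-fold higher number from compound 3 to compound 4 (0.40 log units; beyond the scatter), a shift that may fall in either direction and is unlikely to be large. Compound 4 is accordingly estimated to give about 0.15 mL/min, within a range from 0.04 mL/min to 0.6 mL/min.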

Compound 4, intrinsic clearance in a liver preparation (reported as CLH), per the amount of preparation that the assay uses: 1.51 mL/min
Compound 4: middle estimate off by 10-fold (1.00 log units), on the low side, and the stated range ends below it.
By their numbers in this assay, from the lowest: compound 3; then compounds 1, 4 and 2 (each within the scatter of the next, the first and the last beyond it).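

For the compounds shown here, putting 4-methoxyphenyl in place of 3-fluorophenyl on the aromatic carbon opposite the ring nitrogen gives [ a 25-fold higher number from compound 3 to compound 4 (1.40 log units; beyond the scatter) ] in this assay, so a change at this carbon alone can produce a large step, just as changes on the sulfonyl sulfur did among the earlier compounds. The low number of compound 3 therefore does not come with the 3,5-difluorophenyl group alone: compound 4 keeps that group and yet gives 1.51 mL/min in the same assay. Nothing available here explains why the number rises so much with this swap.

The swap removes a fluorine and brings in a methoxy group while also moving the substituent to a different place on the ring, so these compounds cannot separate those changes; an unsubstituted phenyl, 4-fluorophenyl or 3-methoxyphenyl on the same carbon would be needed to tell them apart. From the compounds shown here alone, it also remains open whether the same swap would have a similar effect alongside the other groups on the sulfonyl sulfur, such as the 4-fluorophenyl of compound 1.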